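The source may report more compounds than this note shows. Statements on the series, on what has been measured and on what is new or still open speak of the compounds shown alone.

Measured so far:
compound 1 `CCOCCOn1c(-c2cccc(C#N)c2)nc(C)c1C(=O)OCC`: 6250 nM
compound 2 `CCOC(=O)c1c(C)nc(-c2cccc(C#N)c2)n1OCc1ccc(C)cc1`: 6310 nM

In a functional assay on a cell-free system (plasma, Oryctolagus cuniculus) for inhibition, with stated times of 5 min, 1 min and 6 min (a lower number here means a stronger inhibitor, a higher number a weaker inhibitor), compound 2 stands level with compound 1, the two values lying within the scatter of each other. The next change leads to compound 3 `CCOC(=O)c1c(C)nc(-c2cccc(C#N)c2)n1OCc1ccccc1C#N`: 2-cyanophenyl in place of 4-methylphenyl on a saturated chain carbon bound to an oxygen on an aromatic ring. Within the data shown here, only one measured step bears on this place, the exchange of ethoxymethyl for 4-methylphenyl: a 1.0-fold higher number from compound 1 to compound 2 (0.00 log units; within the scatter). It is a single step, and 2-cyanophenyl has not been tested at this place. Among the measured compounds shown here, with that step as the only guide, no change beyond the scatter is expected in this assay, in either direction. The value expected for compound 3 is 6000 nM, with an estimated range of 2000 nM to 16000 nM. The estimated step is a 1.1-fold lower number from compound 2 to compound 3 (0.02 log units; within the scatter).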

Compound 3, half-maximal inhibitory concentration: 9380 nM
Estimate against measurement, compound 3: 1.6-fold (0.19 log units) below; measured number inside the range.
By their numbers in this assay, from the lowest: compounds 1, 2 and 3 (each within the scatter of the next).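

In this assay, the place on a saturated chain carbon bound to an oxygen on an aromatic ring now carries a third group, 2-cyanophenyl, and its number stays within the scatter of both earlier compounds (a 1.5-fold higher number from compound 2 to compound 3 (0.17 log units; within the scatter); a 1.5-fold higher number from compound 1 to compound 3 (0.18 log units; within the scatter)). The entering group adds a nitrile and a hydrogen-bond acceptor to the aromatic ring, yet ethoxymethyl, 4-methylphenyl and 2-cyanophenyl cannot be told apart at this place in this series. No supporting data are available to account for this flat reading.

On these data alone, whether any group at this place can move the number beyond the scatter remains open, for example an amine or a carboxylic acid in place of the aromatic ring. As far as these compounds go, it is also open whether 4-cyanophenyl would read the same as 2-cyanophenyl.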